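Moving a chain carbon and reshaping the piperidine end

The source may report more compounds than this note shows. Statements on the series, on what has been measured and on what is new or still open speak of the compounds shown alone.

Of the compounds shown here, two of a shared core have been measured in a physicochemical assay for permeability, using PAMPA; a higher number here means that the compound crosses the layer faster, a lower number that the compound crosses the layer more slowly. Compound 1 `Cc1ccccc1-c1nc(CN2CCC(C(=O)NCCCN3CCC(C(C)C)CC3)CC2)c(C)o1` gives 396 10^-6 cm/s in this assay. Compound 2 `Cc1oc(-c2c(F)cccc2F)nc1CN1CCC(C(=O)NCCCN2C[C@H](C)C[C@H](C)C2)CC1` gives 82.4 10^-6 cm/s in this assay. Of these two numbers, compound 1 stands highest. The gap between compound 1 and compound 2 lies beyond the usual scatter of repeated measurements.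

Compound 3 `Cc1ccccc1-c1nc(CN2CCC(C(=O)NCCCCN3C[C@H](C)C[C@H](C)C3)CC2)c(C)o1` has not yet been measured in this assay. It is built from the same atoms as compound 1, joined differently: (3,5-dimethylpiperidin-1-yl)methyl in place of 4-isopropylpiperidin-1-yl on a saturated chain carbon, three bonds along the chain from an amide-type nitrogen. Put another way, the ring at the far end of the chain is drawn one bond further from the amide, and its substituents are rearranged.

Going by the values given here, no measured pair in this set isolates this change on its own, so the expectation rests on compound 1 alone. Because compound 1 gives 396 10^-6 cm/s, and the change neither adds nor removes any donor or acceptor, the step of a 1.4-fold lower number from compound 1 to compound 3 (0.15 log units; within the scatter) is expected to be small, most likely within the scatter or slightly downward. Compound 3 is therefore estimated at 280 10^-6 cm/s in this assay, within a range from 110 10^-6 cm/s to 550 10^-6 cm/s.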

Compound 3, apparent permeability: 288 10^-6 cm/s
Compound 3: the middle estimate sits 1.0-fold (0.01 log units) below what was measured; low and high end bracket the measured number.
By their numbers in this assay, from the lowest: compound 2; then compounds 3 and 1 (each within the scatter of the next).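

Going by these compounds alone, compound 1 and compound 3 form the first measured pair here that differs in one place, and in this assay that pair gives a 1.4-fold lower number from compound 1 to compound 3 (0.14 log units; within the scatter) as its step. For this end of the molecule, that means the same atoms can be rejoined, with 4-isopropylpiperidin-1-yl giving way to (3,5-dimethylpiperidin-1-yl)methyl and 2 defined stereocentres entering, without the read-out leaving the scatter, though this is one pair and no general rule. No measurement shown here offers an explanation for this result.

This single step combines two things: the ring sits one bond further along the chain, and its carbon substituents are rearranged, so the compounds shown cannot tell whether each alone would leave the number unmoved or whether the two offset one another. They also leave open what would happen if the atoms themselves changed at this chain end, as with a morpholine ring or a carboxylic acid in place of the substituted piperidine.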